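Cytotoxicity of Two Benzyl Groups on One Shared Core

This account rests on a few compounds, and the source may have more. Where it says the series, first, only, none or still open, it means among the compounds named here.

Measured so far in an ADME assay on MT4 cells (Homo sapiens) for cytotoxicity, read by MTT assay, with a stated time of 5 days; on this read-out lower numbers stand for higher toxicity in this test and higher numbers for lower toxicity in this test:
Compound 1, `O=C1N(Cc2ccccc2Cl)c2cccn2S(=O)(=O)N1Cc1ccccc1`, gives only a limit of > 291000 nM in this assay.
Compound 2, `O=C1N(Cc2ccccc2Br)c2cccn2S(=O)(=O)N1Cc1ccccc1`, gives 226000 nM in this assay.

Compound 2 thus holds the only actual number shown in this assay; the other result is a limit, not a number. Among the compounds with values here, the single measured step, an at least 1.2-fold lower number from compound 1 to compound 2 (0.10 log units; that floor lies within the scatter), swaps one halogen for another and sits within the scatter, and because of the limit of > 291000 nM in this assay, at which 1 of the 2 values shown sits, its true size is not pinned down. Compound 3, `O=C1N(Cc2ccc(F)cc2)c2cccn2S(=O)(=O)N1Cc1ccccc1`, differs from compound 2 by 4-fluorophenyl in place of 2-bromophenyl on a saturated chain carbon bound to an amide-type nitrogen in a ring. Within the data shown here, no measured step covers this exact change; the only step available, from compound 1 to compound 2, gives no ground to expect a move beyond the scatter. Compound 3 is therefore expected at 250000 nM, within 120000 nM to 600000 nM. This estimate means a step of a 1.1-fold higher number from compound 2 to compound 3 (0.04 log units; within the scatter), expected to stay within the scatter.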

Compound 3, half-maximal cytotoxic concentration: 150000 nM
Estimate against measurement, compound 3: 1.7-fold (0.22 log units) above, within the range that was stated.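

Within the data shown here, this is the first change at this place that swaps the whole 2-bromophenyl group for 4-fluorophenyl, not just one halogen for another, and in this assay the result still stays within the scatter: a 1.5-fold lower number from compound 2 to compound 3 (0.18 log units; within the scatter). Set against the 2-chlorophenyl group, the reading is an at least 1.9-fold lower number from compound 1 to compound 3 (0.28 log units; that floor lies within the scatter), which gives only a floor. Compound 1 gives a limit, not a number, so the true size of that step stays unknown: the limit of > 291000 nM in this assay, at which 1 of the 3 values shown sits.

Going by these compounds, all three compounds carry a halogen-bearing phenyl group at this place, so what an amine, a carboxylic acid or a longer chain would do there stays open. Also open, on these data alone, is whether any change to the plain benzyl group on the shared core would move the number beyond the scatter.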